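Compound 2 to compound 4: a side chain exchange

The source may report more compounds than this note shows. Statements on the series, on what has been measured and on what is new or still open speak of the compounds shown alone.

compound 1 `O=C1c2c[n+]([O-])c3ccccc3c2C(=O)c2c1c1ccccc1n2Cc1cn([C@H]2O[C@H](CO)[C@@H](O)[C@H]2O)nn1` gives 1490 nM
compound 2 `O=C1c2c[n+]([O-])c3ccccc3c2C(=O)c2c1c1ccccc1n2CCCCn1ccnc1` gives 130 nM
compound 3 `O=C1c2c[n+]([O-])c3ccccc3c2C(=O)c2c1c1ccccc1n2Cc1cn([C@@H]2C[C@H](O)[C@@H](CO)O2)nn1` gives 110 nM

All three values come from a functional assay on MCF7 cells (Homo sapiens) for cytotoxicity, read by MTT assay, with a stated time of 72 h (a lower number here means a stronger inhibitor, a higher number a weaker inhibitor), and compound 2 (130 nM) lies within the scatter of compound 3 (110 nM), while compound 1 (1490 nM) stands far higher than both.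

Compound 4 `O=C1c2c[n+]([O-])c3ccccc3c2C(=O)c2c1c1ccccc1n2CCN1CCCC1` has no value yet. Its difference from compound 2 is pyrrolidin-1-yl in place of 2-(1H-imidazol-1-yl)ethyl on a saturated chain carbon, two bonds along the chain from an aromatic nitrogen and this lies on a saturated chain carbon, two bonds along the chain from an aromatic nitrogen. Cut one bond further out, the same difference reads 4-(1H-imidazol-1-yl)butyl to 2-(pyrrolidin-1-yl)ethyl.

Going by the values given here, the only measured step is a 14-fold lower number from compound 1 to compound 3 (1.13 log units; beyond the scatter) and it is large, but it is a change of hydrogen in place of hydroxy on a saturated ring carbon, which does not occur between compound 2 and compound 4. Among the compounds with values here, no measured compound carries pyrrolidin-1-yl, so the data give no direction for this change. The size of that one step still argues for a wide range. The expected step is a 1.1-fold lower number from compound 2 to compound 4 (0.03 log units; within the scatter) and no shift beyond the scatter is expected in this assay for now. For compound 4 the estimated value is 120 nM (expected range 40 nM to 450 nM).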

Compound 4, half-maximal inhibitory concentration: 320 nM
Estimate against measurement, compound 4: 2.7-fold (0.43 log units) below; the range from low to high includes it.
By their numbers in this assay, from the lowest: compounds 3 and 2 (each within the scatter of the next); then compound 4; then compound 1.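

In this assay, a 2.5-fold higher number from compound 2 to compound 4 (0.39 log units; beyond the scatter) gives the first measured direction for this position: pyrrolidin-1-yl in place of 2-(1H-imidazol-1-yl)ethyl, on a saturated chain carbon, two bonds along the chain from an aromatic nitrogen, moves the number up by a modest step beyond the scatter. Read with the cut one bond further out, 4-(1H-imidazol-1-yl)butyl goes to 2-(pyrrolidin-1-yl)ethyl, so this single step changes the chain and the terminal ring together, with the leaving group at 7 heavy atoms and one five-membered aromatic ring and the entering group at 5 heavy atoms and one five-membered non-aromatic ring. No measurement on these compounds bears on why the number moves.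

The compounds shown leave open whether the step follows the chain or the ring, since no compound here pairs either ring with the other chain. A 4-(pyrrolidin-1-yl)butyl group on the shared core would separate the two, and a morpholine ring or a dimethylamino group on the same chain would show whether the pyrrolidine ring itself matters.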